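The source may hold more compounds than are shown below. What is called first, only, known or untested is meant among the compounds shown, and "the series" means these compounds.

Of the compounds shown here, two sharing one core have been measured in a functional assay on HEK293 cells for agonist activity at lutropin-choriogonadotropic hormone receptor (Homo sapiens), read by cAMP accumulation; a higher number here means a larger maximal response, a lower number a smaller maximal response: compound 1 `COc1cccc(-c2nc(SC)nc3sc(C(=O)NCCO)c(N)c23)c1` gives 20.5%, and compound 2 `COc1cccc(-c2nc(SC)nc3sc(C(=O)NNC(C)(C)C)c(N)c23)c1` gives 6%. Within the data shown here, compound 2 thus stands lowest of the two, the only measured step being a number 14.5 percentage points lower from compound 1 to compound 2 (beyond the scatter). Compound 3 `CCNC(=O)c1sc2nc(SC)nc(-c3cccc(OC)c3)c2c1N` differs from compound 2 by ethyl in place of (tert-butyl)amino on an amide-type nitrogen. Among the measured compounds shown here, that one step is the only guide: it shows the group on this nitrogen matters, and moving away from (tert-butyl)amino is expected to recover part of the lost response, so compound 3 is estimated at 15% (range 3% to 30%), meaning an expected a number 9 percentage points higher from compound 2 to compound 3 (within the scatter).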

Compound 3, largest response reached (reported as efficacy), in percent of the reference or control that the assay uses: 26.9%
Compound 3: middle estimate off by 11.9 percentage points, on the low side; measured number inside the range.
By their numbers in this assay, from the lowest: compound 2; then compounds 1 and 3 (each within the scatter of the next).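

Replacing (tert-butyl)amino with ethyl gives a number 20.9 percentage points higher from compound 2 to compound 3 (beyond the scatter) in this assay and so ties the low response of compound 2 to the group on this amide-type nitrogen. Removing the hydroxy from the chain gives a number 6.4 percentage points higher from compound 1 to compound 3 (within the scatter) and so the ethyl and 2-hydroxyethyl groups cannot be told apart in this assay. No supporting evidence is available to explain either step.

Going by these compounds, whether a longer chain such as butyl, or a chain bearing an amine or a carboxylic acid, would raise the maximal response remains open.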